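Swapping the Group on the Ring Nitrogen

The source may hold more compounds than are shown below. What is called first, only, known or untested is meant among the compounds shown, and "the series" means these compounds.

Compound 1 `CN(C)c1ccc(C(=O)N2CCC(NS(=O)(=O)c3cc(S(=O)(=O)c4ccccc4)ccc3C(F)(F)F)CC2)cn1`, compound 2 `O=C(O)c1cccc(S(=O)(=O)N2CCC(NS(=O)(=O)c3cc(S(=O)(=O)c4ccccc4)ccc3C(F)(F)F)CC2)c1` and compound 3 `O=C(O)c1ccc(S(=O)(=O)N2CCC(NS(=O)(=O)c3cc(S(=O)(=O)c4ccccc4)ccc3C(F)(F)F)CC2)cc1` share one core but differ in the group on an amine nitrogen in a ring. In a physicochemical assay for solubility (on this read-out higher numbers stand for higher solubility and lower numbers for lower solubility), compound 1 gives 12500 nM and compound 2 gives 12500 nM, while compound 3 gives 12500 nM and so stands level with both. Compound 4 `CC(C)(O)CCN1CCC(NS(=O)(=O)c2cc(S(=O)(=O)c3ccccc3)ccc2C(F)(F)F)CC1` is still unmeasured. It carries 3-hydroxy-3-methylbutyl in place of (4-carboxyphenyl)sulfonyl on an amine nitrogen in a ring. Two measured steps change the group on that same nitrogen, one (no change at the digits printed from compound 1 to compound 2 (within the scatter)) and the other (no change at the digits printed from compound 1 to compound 3 (within the scatter)), and a third changes only the carboxyphenyl group (no change at the digits printed from compound 2 to compound 3 (within the scatter)). None of them leaves the scatter, yet none brings in 3-hydroxy-3-methylbutyl, so the evidence is indirect. An estimated step (no change at the digits printed from compound 3 to compound 4 (within the scatter)) is therefore expected in this assay with no direction beyond the scatter. Compound 4 is estimated at 12500 nM with 5000 nM to 25000 nM as its expected range.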

Compound 4, solubility: 50000 nM
Beside the measured number, compound 4's estimate is 4.0-fold (0.60 log units) below it; the measured number lies above the stated range.
By their numbers in this assay, from the lowest: compounds 1, 2 and 3 (each within the scatter of the next); then compound 4.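

In this assay, the group on the amine nitrogen in a ring now shifts the read-out beyond the scatter: 3-hydroxy-3-methylbutyl gives a 4.0-fold higher number from compound 3 to compound 4 (0.60 log units; beyond the scatter) in place of (4-carboxyphenyl)sulfonyl, a 4.0-fold higher number from compound 2 to compound 4 (0.60 log units; beyond the scatter) in place of (3-carboxyphenyl)sulfonyl and a 4.0-fold higher number from compound 1 to compound 4 (0.60 log units; beyond the scatter) in place of (6-(dimethylamino)pyridin-3-yl)carbonyl. Among the compounds shown here, the three earlier groups, all of which carry a ring, stand level, so this nitrogen is not indifferent to what it carries, and the one group with no ring is the one that stands apart. Nothing shown here accounts for this rise.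

The compounds shown leave open which feature of 3-hydroxy-3-methylbutyl goes with the higher number: its hydroxyl, its branching or its open chain. A 3-methylbutyl chain without the hydroxyl, a shorter 2-hydroxyethyl chain or a chain ending in an amine on the same nitrogen could tell these apart.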